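Propyl Extension on the Aromatic-Nitrogen Chain: Compound 3

The source may report more compounds than this note shows. Statements on the series, on what has been measured and on what is new or still open speak of the compounds shown alone.

Compound 1 `CC(=O)N1CCc2c(c(-c3ccc(OC(F)(F)F)cc3)nn2CC(O)CN2CCC(n3c(O)nc4ccccc43)CC2)C1`: 130 nM
Compound 2 `CC(=O)N1CCc2c(c(-c3ccc(Cl)c(C)c3)nn2CC(O)CN2CCC(n3c(=O)n(C)c4ccccc43)CC2)C1`: 500 nM

In an assay on isolated protein for inhibition of cathepsin S (Homo sapiens) (a higher number here means a weaker inhibitor, a lower number a stronger inhibitor), compound 2 gives 500 nM, the higher of the two numbers. Compound 1 gives 130 nM in this assay, a lower number by a gap beyond the scatter. Compound 3 `CCCCn1c(=O)n(C2CCN(CC(O)Cn3nc(-c4ccc(Cl)c(C)c4)c4c3CCN(C(C)=O)C4)CC2)c2ccccc21` differs from compound 2 by propyl in place of hydrogen on a saturated chain carbon bound to an aromatic nitrogen. Going by the values given here, no measured pair shows a step of this kind, so the expectation rests on compound 2 alone. A small step is expected, a 1.2-fold higher number from compound 2 to compound 3 (0.08 log units; within the scatter), not clearly beyond the scatter in either direction. Compound 3 is expected to give 600 nM in this assay, within a range of 200 nM to 1800 nM.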

Compound 3, half-maximal inhibitory concentration: 140 nM
Estimate against measurement, compound 3: 4.3-fold (0.63 log units) above; the measured number lies below the stated range.
By their numbers in this assay, from the lowest: compounds 1 and 3 (each within the scatter of the next); then compound 2.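

In this assay, propyl in place of hydrogen on a saturated chain carbon bound to an aromatic nitrogen gives a 3.6-fold lower number from compound 2 to compound 3 (0.55 log units; beyond the scatter) and shows that this position tolerates growth from methyl to butyl, with a stronger inhibitor as the outcome. The earlier compounds shown here offered no step at this place. Nothing measured here bears on the reason for this step.

One pair sets no trend with chain length. On these data alone, whether ethyl, a longer chain such as hexyl, or a butyl chain ending in an amine or a carboxylic acid would behave alike remains open.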